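Glucagon receptor series: ethyl to isopropyl step

The source may hold more compounds than are shown below. What is called first, only, known or untested is meant among the compounds shown, and "the series" means these compounds.

Measured compounds:
compound 1 `CCCCCc1c(C(C)C)nc(C(C)C)c(CO)c1-c1ccc(CC)cc1`: 42%
compound 2 `CCCCCc1c(C(C)C)nc(C(C)C)c(CO)c1-c1cccc(C(F)(F)F)c1`: 25%

Going by the values given here, in an assay on CHO cells for inhibition of Glucagon receptor (Homo sapiens), tested at 20 uM (a lower number here means less inhibition, a higher number more inhibition at the concentration tested (going by the name of the read-out)), compound 1 gives 42%, the higher of the two numbers measured so far; compound 2 gives 25%, a number lower by a margin beyond the usual scatter. Among the compounds with values here, the two differ in several places at once, so no single step is separated out from them. Compound 3 `CCCCCc1c(C(C)C)nc(C(C)C)c(CO)c1-c1ccc(C(C)C)cc1` is not yet measured. It differs from compound 1 in one place: methyl in place of hydrogen on a saturated chain carbon bound to an aromatic carbon and a saturated chain carbon. Read one bond further out, this is ethyl to isopropyl, 4-ethylphenyl to 4-isopropylphenyl. Within the data shown here, no step between measured compounds covers this change, so the size of its effect in this assay is unknown from the numbers at hand. For compound 3 the expected step of a number 3 percentage points higher from compound 1 to compound 3 (within the scatter) is small, not beyond the scatter in either direction. Compound 3 is accordingly estimated at 45%, with a range from 25% to 65%.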

Compound 3, a percentage reported as inhibition, at one concentration (the size of the read-out at that concentration, not a potency): 34%
Compound 3: middle estimate off by 11 percentage points, on the high side; measured number inside the range.
By their numbers in this assay, from the lowest: compounds 2, 3 and 1 (each within the scatter of the next, the first and the last beyond it).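

In this assay, going by these compounds alone, methyl in place of hydrogen on a saturated chain carbon bound to an aromatic carbon and a saturated chain carbon gives a number 8 percentage points lower from compound 1 to compound 3 (within the scatter) as the first step that isolates a single place. Ethyl to isopropyl at this position therefore leaves the read-out inside the usual scatter, and 4-ethylphenyl and 4-isopropylphenyl cannot be told apart at the concentration tested. Nothing at hand bears on the reason for this result.

Still open, from the compounds shown here alone, is whether this position responds to a larger departure from ethyl, such as a longer chain like butyl, or to a different kind of group, such as an amine or a carboxylic acid. The single-concentration read-out also leaves open whether compound 1 and compound 3 would differ in potency.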